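This account rests on a few compounds, and the source may have more. Where it says the series, first, only, none or still open, it means among the compounds named here.

In an ADME assay on the whole organism (plasma, Mus musculus, strain CD-1) for protein binding, read by LC-MS, with a stated time of 24 h (on this read-out higher numbers stand for a larger free fraction and lower numbers for a smaller free fraction), compound 2 `Cc1nc(-c2nnn(C)c2COC(=O)N(C)CC2CCC2)ccc1O[C@H]1CCC[C@H](C(=O)O)C1` gives 0.1 and lies within the scatter of compound 3 `CN(C(=O)OCc1c(-c2ccc(O[C@H]3CCC[C@H](C(=O)O)C3)cn2)nnn1C)C1CCCC1` at 0.083 while compound 1 `CN(CC1CCC1)C(=O)OCc1c(-c2ccc(O[C@H]3CCC[C@H](C(=O)O)C3)c(C(F)F)n2)nnn1C` at 0.035 lies lower, beyond the scatter. Compound 4 `CCCCN(C)C(=O)OCc1c(-c2ccc(O[C@H]3CCC[C@H](C(=O)O)C3)c(C)n2)nnn1C` carries the change propyl in place of cyclobutyl on a saturated chain carbon bound to an amide-type nitrogen with propyl in place of cyclobutyl on a saturated chain carbon bound to an amide-type nitrogen, which also reads as cyclobutylmethyl to butyl. Within the data shown here, the one measured step of a 2.9-fold higher number from compound 1 to compound 2 (0.46 log units; beyond the scatter) is modest and beyond the scatter but concerns methyl in place of difluoromethyl on an aromatic carbon, so it sets no size for this change. Among the measured compounds shown here, no measured step covers this place, so no shift beyond the scatter is expected in this assay here. The estimated step is a 1.1-fold lower number from compound 2 to compound 4 (0.05 log units; within the scatter) and stays within the scatter. Compound 4 is expected at 0.09 with an estimated range of 0.05 to 0.17.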

Compound 4, unbound fraction: 0.134
The estimate for compound 4 lay 1.5-fold (0.17 log units) below the measured number; low and high end bracket the measured number.
By their numbers in this assay, from the lowest: compound 1; then compounds 3, 2 and 4 (each within the scatter of the next).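

In this assay, replacing cyclobutyl with propyl on a saturated chain carbon bound to an amide-type nitrogen gives a 1.3-fold higher number from compound 2 to compound 4 (0.13 log units; within the scatter). Among these compounds, this is the first reading of a change at this position, and for this pair the four-membered ring is not required to keep the unbound fraction at this level. Nothing at hand gives a cause for this step.

From the compounds shown here alone, whether an amine, a hydroxyl or a chain longer than butyl here would shift the number beyond the scatter remains open. Also open, going by these compounds, is whether the same change behaves alike with difluoromethyl in place of methyl.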